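Methyl for Fluoro: What to Expect of Compound 3

This account rests on a few compounds, and the source may have more. Where it says the series, first, only, none or still open, it means among the compounds named here.

Compound 1 `O=[N+]([O-])c1ccc(-c2nnc(-c3cccnc3)n2Nc2nc3ccc(F)cc3s2)cc1` gives >= 108 ug/mL in an ADME assay on MT4 cells (Homo sapiens) for cytotoxicity, read by MTT assay, with a stated time of 5 days; a higher number here means that more compound is tolerated, a lower number that less compound is tolerated; this value is a limit of the assay, not a number.
Compound 2 `Fc1ccc2nc(Nn3c(-c4ccc(Cl)cc4)nnc3-c3cccnc3)sc2c1` gives 92.9 ug/mL in this assay.

Within the data shown here, compound 2 carries the only measured number in this assay; the one further value shown, that of compound 1, is a limit (the limit of >= 108 ug/mL in this assay, at which 1 of the 2 values shown sits). Among the measured compounds shown here, the single measured step, an at least 1.1-fold lower number from compound 1 to compound 2 (0.06 log units; that floor lies within the scatter), lies within the scatter, so the exchange of nitro for chloro left tolerance essentially unchanged. Compound 3 `Cc1ccc2nc(Nn3c(-c4ccc(Cl)cc4)nnc3-c3cccnc3)sc2c1` differs from compound 2 by methyl in place of fluoro on an aromatic carbon. For the measured compounds named here, no measured step touches that position, and the one step that is known produced no shift beyond the scatter; for compound 3 in this assay no change beyond the scatter is therefore expected in either direction. Compound 3 is estimated at 85 ug/mL, between 40 ug/mL and 150 ug/mL. This estimate corresponds to an expected step of a 1.1-fold lower number from compound 2 to compound 3 (0.04 log units; within the scatter).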

Compound 3, half-maximal cytotoxic concentration: 75.5 ug/mL
Beside the measured number, compound 3's estimate is 1.1-fold (0.05 log units) above it; low and high end bracket the measured number.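

In this assay, methyl in place of fluoro on this aromatic carbon, part of a fused or bridged system of two rings, gives a 1.2-fold lower number from compound 2 to compound 3 (0.09 log units; within the scatter). This position, which the earlier step did not touch, thus has a measured step of its own, and fluoro and methyl are not told apart there by this read-out. The value of compound 1 remains a limit of the assay, not a number: the limit of >= 108 ug/mL in this assay, at which 1 of the 3 values shown sits.

As far as these compounds go, whether an amine, a carboxylic acid or a longer chain on this carbon would move the number beyond the scatter stays open. The compounds shown also leave open whether methyl in place of fluoro would give a step of similar size on a different core.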